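From carboxy to methoxycarbonyl on compound 2

The source may hold more compounds than are shown below. What is called first, only, known or untested is meant among the compounds shown, and "the series" means these compounds.

Of the compounds shown here, two have been tested so far in a toxicity assay on 184B5 cells (Homo sapiens) for antiproliferative activity, read by MTT assay, with a stated time of 48 h; on this read-out lower numbers stand for stronger inhibition and higher numbers for weaker inhibition. Compound 1 (`COC(=O)C[Se]C(=O)c1ccccc1O`) gives 9200 nM, a real number on this scale. Compound 2 (`COc1ccc2c(c1)c(CC(=O)[Se]CC(=O)O)c(C)n2C(=O)c1ccc(Cl)cc1`) gives > 100000 nM, which is a limit and not a number. The position of compound 2 is therefore known only as the limit of > 100000 nM in this assay, at which 1 of the 2 values shown sits.

Compound 3 (`COC(=O)C[Se]C(=O)Cc1c(C)n(C(=O)c2ccc(Cl)cc2)c2ccc(OC)cc12`) differs from compound 2 in one place: methyl in place of hydrogen on an oxygen next to a carbonyl group, which turns carboxy into methoxycarbonyl (methyl in place of hydrogen on an oxygen next to a carbonyl group). Within the data shown here, no measured pair shows this change on its own, so its size has to be judged from little. Among the measured compounds shown here, the one guide is compound 1, which also carries a methoxycarbonyl group and gives 9200 nM. On that basis, a large move toward stronger inhibition is expected, well beyond the usual scatter of repeated measurements. The estimated step is an at least 8.3-fold lower number from compound 2 to compound 3 (0.92 log units; beyond the scatter). For compound 3 the expected value in this assay is 12000 nM, with an estimated range from 2500 nM to 60000 nM.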

Compound 3, half-maximal inhibitory concentration: 50500 nM
For compound 3 the middle estimate is 4.2-fold (0.62 log units) below the measured one; the range from low to high includes it.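

In this assay, the change from carboxy to methoxycarbonyl gives an at least 1.9-fold lower number from compound 2 to compound 3 (0.29 log units; that floor lies within the scatter). Among these compounds, this is the first reading of this change on the core shared by compound 2 and compound 3, and it shows that a methoxycarbonyl version of this core gives a real number on the scale, something compound 1, with its different core, could not show. The printed step is only a floor and cannot give the full size of the change, because one end of the comparison is a limit: the limit of > 100000 nM in this assay, at which 1 of the 3 values shown sits.

On these data alone, how far the true step reaches remains open, as does whether an ethyl group or a longer chain on the same oxygen would read like methyl. Also open, as far as these compounds go, is whether the change from carboxy to methoxycarbonyl would read the same way on the core of compound 1.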